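A few compounds are considered here, and "the series" means these few. Any claim that something is new, unique, unknown or untested is made for them only; others in the source may bear on it.

Measured in a functional assay on B16-F10 cells (Mus musculus) for antiproliferative activity, read by MTT assay, with a stated time of 48 h; a lower number here means a stronger inhibitor, a higher number a weaker inhibitor:
compound 1 `COc1ccc(C2OC(c3ccc4ccccc4c3)=NN2C(C)=O)cc1`: 6.86 ug/mL
compound 2 `CC(=O)N1N=C(c2ccc3ccccc3c2)OC1c1ccccc1F`: 6.05 ug/mL
compound 3 `CC(=O)N1N=C(c2ccc3ccccc3c2)OC1c1ccccc1O`: 2.58 ug/mL

Compound 3 has the lowest number of the three, and its steps to both others lie beyond the scatter. Compound 4 `CC(=O)N1N=C(c2ccc3ccccc3c2)OC1c1cccnc1` carries pyridin-3-yl in place of 2-hydroxyphenyl on a saturated ring carbon.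

Within the data shown here, two measured steps bear on this change, a 2.7-fold lower number from compound 1 to compound 3 (0.42 log units; beyond the scatter) and a 2.3-fold lower number from compound 2 to compound 3 (0.37 log units; beyond the scatter), both modest and both bringing in the 2-hydroxyphenyl that compound 4 lacks. The third, a 1.1-fold lower number from compound 1 to compound 2 (0.05 log units; within the scatter), stays within the scatter. Among the measured compounds shown here, no measured compound carries pyridin-3-yl, so these steps, read in reverse, are only a guide. A modest rise in this assay is therefore expected, and the estimated step is a 2.3-fold higher number from compound 3 to compound 4 (0.37 log units; beyond the scatter). The estimate for compound 4 is 6 ug/mL, with an expected range of 2.8 ug/mL to 13 ug/mL.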

Compound 4, half-maximal inhibitory concentration: 3.06 ug/mL
For compound 4 the middle estimate is 2.0-fold (0.29 log units) above the measured one; the measured number falls inside the stated range.
By their numbers in this assay, from the lowest: compounds 3, 4, 2 and 1 (each within the scatter of the next, the first and the last beyond it).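

In this assay, the hydroxy group is not needed at this saturated ring carbon for a number in the range of compound 3: pyridin-3-yl, with no hydrogen-bond donor, gives a 1.2-fold higher number from compound 3 to compound 4 (0.07 log units; within the scatter). Among these compounds, the same group gives a 2.0-fold lower number from compound 2 to compound 4 (0.30 log units; within the scatter) and a 2.2-fold lower number from compound 1 to compound 4 (0.35 log units; beyond the scatter), so only the step from the 4-methoxyphenyl compound clears the scatter. No measurement shown here offers an explanation for these steps.

As far as these compounds go, how a pyridin-4-yl or a 2-aminophenyl group would read on this carbon remains open.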